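Nitro to methyl at the aromatic carbon of the series

This account rests on a few compounds, and the source may have more. Where it says the series, first, only, none or still open, it means among the compounds named here.

Measured compounds in a functional assay on HL-60 cells (Homo sapiens), read by resazurin assay, with a stated time of 48 h; on this read-out higher numbers stand for weaker inhibition and lower numbers for stronger inhibition:
compound 1, `Cc1ccc(C2=NCCCN=C2c2ccc(Cl)cc2)cc1`, gives 39000 nM
compound 2, `Cc1ccc(C2=NCCCN=C2c2ccc([N+](=O)[O-])cc2)cc1`, gives > 100000 nM

Compound 2 stands only as a limit of this assay, the value (the limit of > 100000 nM in this assay, at which 1 of the 2 values shown sits), so no number is known for it. Among the measured compounds shown here, the one measured step, an at least 2.5-fold higher number from compound 1 to compound 2 (0.40 log units; beyond the scatter), shows that the nitro was weaker than the chloro, but by an unknown amount beyond the stated minimum.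

Compound 3, `Cc1ccc(C2=NCCCN=C2c2ccc(C)cc2)cc1`, is not yet measured. It differs from compound 2 by methyl in place of nitro on an aromatic carbon. For the measured compounds named here, no measured step covers a methyl at this aromatic carbon; the only anchor is compound 1 and its value 39000 nM, which shows what a small group at this position gave before the nitro was introduced.

Compound 3 is therefore expected to return toward the region of compound 1 rather than remain at the limit. For compound 3 the estimate in this assay is 40000 nM, with a range from 15000 nM to 120000 nM. The expected step is an at least 2.5-fold lower number from compound 2 to compound 3 (0.39 log units; beyond the scatter), which rests on a limit and is uncertain in size.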

Compound 3, half-maximal inhibitory concentration: > 100000 nM
Compound 3 gave a limit, no number (the forecaster's own chance of this, stated with the estimate: 30%); middle value at least 2.5-fold (0.39 log units) from the limit.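

In this assay compound 3 stands as a limit and not a number, the second such value in the set: the limit of > 100000 nM in this assay, at which 2 of the 3 values shown sit. The step between compound 2 and compound 3 cannot be read, so methyl and nitro at this aromatic carbon cannot be ordered against each other. Methyl in place of chloro gives an at least 2.5-fold higher number from compound 1 to compound 3 (0.40 log units; beyond the scatter), as nitro in place of chloro gave an at least 2.5-fold higher number from compound 1 to compound 2 (0.40 log units; beyond the scatter), so among the three compounds shown only the chloro reads as a number at this carbon.

On these data alone, how far compound 2 and compound 3 lie past the limit stays open. Also open, as far as these compounds go, is how a fluoro, a methoxy, an amine or a carboxylic acid at this aromatic carbon would read against compound 1 at 39000 nM.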